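The source may hold more compounds than are shown below. What is called first, only, known or untested is meant among the compounds shown, and "the series" means these compounds.

Compounds measured in an assay on isolated protein for inhibition of retinal dehydrogenase 2 (Homo sapiens); a higher number here means a weaker inhibitor, a lower number a stronger inhibitor:
compound 1, `CC(Sc1nc2c(cnn2C)c(=O)n1-c1ccccc1)c1cccnc1`, 89 nM
compound 2, `CC(Sc1nc2c(cnn2C)c(=O)n1-c1ccccc1)c1cccc(O)c1`, 100 nM
compound 3, `CC(Sc1nc2c(cnn2C)c(=O)n1-c1ccccc1)c1ccccc1`, 110 nM

Compound 3 has the highest of the three numbers, but its steps to the others, a 1.2-fold higher number from compound 1 to compound 3 (0.09 log units; within the scatter) and a 1.1-fold higher number from compound 2 to compound 3 (0.04 log units; within the scatter), are both within the scatter, so the three compounds cannot be ordered on these numbers. Compound 4, `C[C@H](Sc1nc2c(cnn2C)c(=O)n1-c1ccccc1)c1ccccc1`, differs from compound 3 only in that (the two compounds have the same atoms and bonds; at least one stereo element is drawn with a configuration in one of them and without one in the other: 1 of 1 stereo elements differ; a stereocentre at a saturated chain carbon is drawn without a configuration in compound 3 and S in compound 4). Among the compounds with values here, none of the measured steps changes a stereocentre; they all swap a group on the saturated chain carbon or on the ring, and each of them, including a 1.1-fold higher number from compound 1 to compound 2 (0.05 log units; within the scatter), stayed within the scatter. Within the data shown here, no measured step therefore bears directly on this change. A single drawn configuration may give a number that is lower or higher than the undefined mixture, and the data give no guide to which. Compound 4 is expected to give about 100 nM, within 40 nM to 300 nM, a step of a 1.1-fold lower number from compound 3 to compound 4 (0.04 log units; within the scatter).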

Compound 4, half-maximal inhibitory concentration: 1480 nM
Estimate against measurement, compound 4: 15-fold (1.17 log units) below, outside the stated range (above it).
By their numbers in this assay, from the lowest: compounds 1, 2 and 3 (each within the scatter of the next); then compound 4.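

In this assay the ring swaps on this saturated chain carbon all stayed within the scatter, but drawing its stereocentre as S brings a large step, a 13-fold higher number from compound 3 to compound 4 (1.13 log units; beyond the scatter), and so shows that configuration at this position can matter far more than those swaps did. Nothing else separates the pair, so the large step can be traced to this one difference: the fact that one of compounds 3 and 4 is drawn with a defined configuration and the other without, at the place where they differ. The large steps of a 15-fold higher number from compound 2 to compound 4 (1.17 log units; beyond the scatter) and a 17-fold higher number from compound 1 to compound 4 (1.22 log units; beyond the scatter) each change the ring and the drawn configuration together, so neither can be read as the effect of one change.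

From the compounds shown here alone, what the R form alone would give remains open, as does the makeup of compound 3. Also open, going by these compounds, is whether an amine on the phenyl ring, or a longer chain on the saturated chain carbon, would fare differently in each configuration.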